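The source may report more compounds than this note shows. Statements on the series, on what has been measured and on what is new or still open speak of the compounds shown alone.

Measured compounds in a functional assay on MGC-803 cells (Homo sapiens) for inhibition, read by MTT assay, with a stated time of 72 h; on this read-out lower numbers stand for stronger inhibition and higher numbers for weaker inhibition:
Compound 1, `O=C(CSc1nc(Nc2ccccc2)c2ccccc2n1)Nc1cccc(Cl)c1`, gives 14300 nM.
Compound 2, `C=CC(=O)Nc1cccc(NC(=O)CSc2nc(Nc3ccccc3)c3ccccc3n2)c1`, gives 7310 nM.
Compound 3, `O=C(CSc1nc(Nc2ccccc2)c2ccccc2n1)Nc1ccc(F)cc1`, gives only a limit of the assay, > 50000 nM, as noted in the limit of > 50000 nM in this assay, at which 1 of the 3 values shown sits.

Among the two numbers shown, compound 2 has the lower one; its nearest neighbour is compound 1, with a 2.0-fold lower number from compound 1 to compound 2 (0.29 log units; within the scatter), so the two cannot be told apart. Compound 4, `C=CC(=O)Nc1cccc(NC(=O)CSc2nc(Nc3ccccc3F)c3ccccc3n2)c1`, differs from compound 2 by fluoro in place of hydrogen on an aromatic carbon.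

For the measured compounds named here, none of the measured steps alters this anilino ring. The step of an at least 3.4-fold higher number from compound 1 to compound 3 (0.54 log units; beyond the scatter) and the step of an at least 6.8-fold higher number from compound 2 to compound 3 (0.83 log units; beyond the scatter) both exchange the ring on the amide-type nitrogen and both bring higher numbers, but they change position and group together and concern the other end of the molecule, so they bear on the present change only loosely. In this assay, no step beyond the scatter is therefore expected for this small addition, with some room for a higher number.

Compound 4 is estimated to give 8500 nM, in the range 3000 nM to 25000 nM. That estimate corresponds to an expected step of a 1.2-fold higher number from compound 2 to compound 4 (0.07 log units; within the scatter).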

Compound 4, half-maximal inhibitory concentration: 26100 nM
Compound 4: the middle estimate sits 3.1-fold (0.49 log units) below what was measured; the measured number lies above the stated range.
By their numbers in this assay, from the lowest: compounds 2, 1 and 4 (each within the scatter of the next, the first and the last beyond it). At a limit, above all of these: compound 3.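

In this assay the anilino ring proves sensitive to a very small change: a single fluoro, ortho to a large group, gives a 3.6-fold higher number from compound 2 to compound 4 (0.55 log units; beyond the scatter). For the compounds shown here, this is the first measured change at this ring, and it shows that the anilino end of the molecule, and not only the ring on the amide-type nitrogen, can move the number while the (vinylcarbonyl)amino group stays in place. Nothing shown gives a cause for this step.

From the compounds shown here alone, it remains open whether the higher number belongs to fluoro itself or would follow any group at this place, such as a methyl or a methoxy group, and whether a group elsewhere on this ring would act alike. Going by these compounds, it is also open whether the same addition would carry over to compound 1, with its 3-chlorophenyl ring.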